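This account rests on a few compounds, and the source may have more. Where it says the series, first, only, none or still open, it means among the compounds named here.

Measured so far:
compound 1, `NCCCCN(C[C@@H]1Cc2cccnc2CN1)[C@H]1CCCc2cccnc21`, 37%;
compound 2, `CN(C[C@@H]1Cc2ncccc2CN1)[C@H]1CCCc2cccnc21`, 1%;
compound 3, `NC(=O)NCCCCN(C[C@H]1Cc2ncccc2CN1)[C@H]1CCCc2cccnc21`, 1%.

In an ADME assay on microsomes from liver (Rattus norvegicus) for metabolic stability, using NADPH, with a stated time of 10 min (a lower number here means that less of the compound is left, a higher number that more of the compound is left), compound 3 stands level with compound 2 at the digits shown, and the two together give the lowest numbers of the three. Compound 1 lies furthest from compound 3, a number well beyond the scatter higher. Compound 4, `c1cnc2c(c1)CN[C@@H](CN(CCCC1CCNCC1)[C@H]1CCCc3cccnc31)C2`, has not yet been measured. It differs from compound 3 in one place: piperidin-4-yl in place of ureidomethyl on a saturated chain carbon, three bonds along the chain from an amine nitrogen. For the measured compounds named here, since no step between measured compounds is given, an expectation for compound 4 can rest only on the numbers of compounds 2 and 3 and on the change itself. Compound 4 is expected to show a small upward step, a number 5 percentage points higher from compound 3 to compound 4 (within the scatter), possibly none beyond the scatter. Compound 4 is estimated at 6%, within 0% to 25%.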

Compound 4, percent of the compound remaining: 40%
Beside the measured number, compound 4's estimate is 34 percentage points below it, outside the stated range (above it).
By their numbers in this assay, from the lowest: compounds 2 and 3 (each within the scatter of the next); then compounds 1 and 4 (each within the scatter of the next).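

In this assay putting piperidin-4-yl in place of ureidomethyl on a saturated chain carbon, three bonds along the chain from an amine nitrogen, gives a number 39 percentage points higher from compound 3 to compound 4 (beyond the scatter) and so shows that the read-out responds strongly to the group carried at this place on the chain. The earlier compounds shown here offered no step from which this could be seen. Nothing given here explains the size of this step.

As far as these compounds go, whether the step follows the ring or its nitrogen stays open, and a cyclohexyl group at the same place would separate the two. From the compounds shown here alone, how a morpholin-4-yl group would fare there is also open.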